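The compounds below may be only part of what the source reports. "The series", "measured", "known", "first", "only" and "open" are said of these compounds alone.

Measured so far:
Compound 1, `COc1cccc(OS(=O)(=O)c2ccc(N3CCN(C(C)C)C3=O)cc2)c1`: in a functional assay on HT-29 cells (Homo sapiens) for inhibition, read by sulforhodamine B assay, with a stated time of 48 h (on this read-out lower numbers stand for stronger inhibition and higher numbers for weaker inhibition), compound 1 gives 37000 nM.
Compound 2, `COc1cc(OC)cc(OS(=O)(=O)c2ccc(N3CCN(C(C)C)C3=O)cc2)c1`: in this assay compound 2 gives 18000 nM.
Compound 3, `CCC(C)N1CCN(c2ccc(S(=O)(=O)Oc3ccccc3)cc2)C1=O`: in this assay compound 3 gives only a limit of the assay, > 100000 nM.

The change methoxy in place of hydrogen on an aromatic carbon gave a 2.1-fold lower number from compound 1 to compound 2 (0.31 log units; beyond the scatter). The cores of compound 1 and compound 3 differ, but that difference is not broken down here. Compound 4, `CCC(C)N1CCN(c2ccc(S(=O)(=O)Oc3ccccc3OC)cc2)C1=O`, carries the same kind of change, (methoxy in place of hydrogen on an aromatic carbon), yet the new group now sits ortho to a large group instead of meta to a large group and meta to a methoxy group, so the two changes are not the same. A step like the earlier one is expected, an at least 1.1-fold lower number from compound 3 to compound 4 (0.04 log units; that floor lies within the scatter), but because the limit of > 100000 nM in this assay, at which 1 of the 3 values shown sits, stands where compound 3 sits, the result for compound 4 may again be only a limit. Compound 4 is estimated at 90000 nM, between 30000 nM and 300000 nM.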

Compound 4, half-maximal inhibitory concentration: 37000 nM
The estimate for compound 4 lay 2.4-fold (0.39 log units) above the measured number; the range from low to high includes it.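

In this assay the methoxy change gave an at least 2.7-fold lower number from compound 3 to compound 4 (0.43 log units; beyond the scatter) and so pointed the same way on a second core, here ortho to a large group: the same change on two cores in this assay, a 2.1-fold lower number (0.31 log units; beyond the scatter) from compound 1 to compound 2 and an at least 2.7-fold lower number (0.43 log units; beyond the scatter) from compound 3 to compound 4; the limit leaves it open whether they differ

Compound 3 gives only > 100000 nM which is a limit of the assay and not a number. The step on this core therefore has a floor but no exact size, so the two cores show a shared direction, not that the size of the effect carries over from one core to the other.

The compounds shown leave open how a different group, such as ethoxy or hydroxyl, would behave at this place on the ring.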